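A few compounds are considered here, and "the series" means these few. Any claim that something is new, unique, unknown or untested is made for them only; others in the source may bear on it.

Measured compounds in a functional assay with Cavia porcellus as the target; a lower number here means a stronger inhibitor, a higher number a weaker inhibitor:

Compound 1 `CC(C)(C)NCC#CCCC(=O)C(O)(c1ccccc1)C1CCCCC1` gives 4300 nM.
Compound 2 `CCN(CC)CC#CCCC(=O)C(O)(c1ccccc1)C1CCCCC1` gives 175 nM.
Compound 3 `CC(C)N(CC#CCCC(=O)C(O)(c1ccccc1)C1CCCCC1)C(C)C` gives 260 nM.

Compound 2 has the lowest number of the three in this assay; compound 3 sits within the scatter of it, while compound 1 is well apart, as the step of a 25-fold lower number from compound 1 to compound 2 (1.39 log units; beyond the scatter) shows.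

The unmeasured compound 4 `CCCCN(CC#CCCC(=O)C(O)(c1ccccc1)C1CCCCC1)CCCC` differs from compound 2 by dibutylamino in place of diethylamino on a saturated chain carbon bound to a triple-bonded carbon.

Among the measured compounds shown here, the steps that bear on this change are the ones on the same saturated chain carbon. From the (tert-butyl)amino compound 1 to the dialkylamino compounds the numbers fell a long way: a 25-fold lower number from compound 1 to compound 2 (1.39 log units; beyond the scatter) and a 17-fold lower number from compound 1 to compound 3 (1.22 log units; beyond the scatter). Between the two dialkylamino compounds the change was small: a 1.5-fold higher number from compound 2 to compound 3 (0.17 log units; within the scatter). For the measured compounds named here, no measured step goes to a dialkylamino group longer than diisopropyl, so the dibutylamino compound 4 is read off the within-scatter step from diethylamino to diisopropylamino.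

For compound 4 in this assay the step of a 1.7-fold higher number from compound 2 to compound 4 (0.23 log units; within the scatter) is expected, that is, nothing beyond the scatter. The estimate for compound 4 is 300 nM, with a range from 100 nM to 1000 nM.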

Compound 4, antagonist equilibrium constant: > 5000 nM
Compound 4 gave a limit, no number (the forecaster's own chance of this, stated with the estimate: 2%); at least 16-fold (1.22 log units) between middle value and limit.
By their numbers in this assay, from the lowest: compounds 2 and 3 (each within the scatter of the next); then compound 1. At a limit, above all of these: compound 4.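

In this assay compound 4 stands only as a limit, not as a number: the limit of > 5000 nM in this assay, at which 1 of the 4 values shown sits. The within-scatter reading for diethylamino and diisopropylamino does not carry over to dibutylamino on this saturated chain carbon bound to a triple-bonded carbon, with an at least 28-fold higher number from compound 2 to compound 4 (1.45 log units; beyond the scatter) and an at least 19-fold higher number from compound 3 to compound 4 (1.28 log units; beyond the scatter), both large. A dialkylamino group alone therefore does not keep the number low, and the comparison with the (tert-butyl)amino group gives only an at least 1.1-fold higher number from compound 1 to compound 4 (0.06 log units; that floor lies within the scatter), so no order can be read for that pair.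

On these data alone, how far the true value of compound 4 lies past its limit stays open. Also open, as far as these compounds go, is whether dipropylamino, or a ring amine such as pyrrolidine, on the same carbon would read with diethylamino or with dibutylamino.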